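Removing a Fluorine from a Scaffold That Shows No Toxicity

The compounds below may be only part of what the source reports. "The series", "measured", "known", "first", "only" and "open" are said of these compounds alone.

In an ADME assay on MT2 cells (Homo sapiens) for cytotoxicity, read by XTT assay, with a stated time of 4 days (on this read-out lower numbers stand for higher toxicity in this test and higher numbers for lower toxicity in this test), compound 1 `Cc1ccc(-c2c3c(nc(C)c2C(OC(C)(C)C)C(=O)O)CCN(c2cccc(-c4ccccc4)c2)C3)cc1` gives > 40000 nM, which is a limit of the assay rather than a number. Compound 2 `Cc1nc2c(c(-c3cc(F)c4c(c3C)CCCO4)c1[C@H](OC(C)(C)C)C(=O)O)CN(CC1CC1c1ccccc1)CC2` likewise gives > 40000 nM, also a limit. Compound 3 `Cc1ccc(CCCN2CCc3nc(C)c([C@H](OC(C)(C)C)C(=O)O)c(-c4cc(F)c5c(c4C)CCCO5)c3C2)cc1F` stands at > 40000 nM, again only a limit. The step that the two limits leave unreadable from compound 2 to compound 3 therefore cannot be read, because both of its ends sit at the limit of > 40000 nM in this assay, at which 3 of the 3 values shown sit. Compound 4 `Cc1ccc(CCCN2CCc3nc(C)c([C@H](OC(C)(C)C)C(=O)O)c(-c4cc(F)c5c(c4C)CCCO5)c3C2)cc1` differs from compound 3 by hydrogen in place of fluoro on an aromatic carbon. Going by the values given here, no measured step shows what hydrogen in place of fluoro does here, and every value known sits at the same limit. The expectation is that compound 4 also stays at the limit, so the step that the limit leaves unreadable from compound 3 to compound 4 is estimated as nothing beyond the scatter. Compound 4 is estimated at 50000 nM, within 25000 nM to 150000 nM.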

Compound 4, half-maximal cytotoxic concentration: > 40000 nM
Compound 4 gave a limit, no number; the forecaster's own chance of this, stated with the estimate: 90%; the middle value does not contradict the limit.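

Compound 4 also gives only a limit, so no step among compound 2, compound 3 and compound 4 can be read: the limit of > 40000 nM in this assay, at which 4 of the 4 values shown sit.

The compounds shown leave open whether hydrogen in place of fluoro changes anything in this assay, and at what concentration any of them becomes toxic.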